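A few compounds are considered here, and "the series" means these few. Any claim that something is new, unique, unknown or untested is made for them only; others in the source may bear on it.

Measured compounds:
Compound 1 `O=C(CCc1ccccc1Br)Nc1nc2ccccc2c(=O)s1`: in an assay on membranes from brain for displacement of a labelled ligand from adenosine receptor A1 (Rattus norvegicus), read by scintillation counting, with a stated time of 90 min (on this read-out higher numbers stand for weaker inhibition and lower numbers for stronger inhibition), compound 1 gives > 10000 nM, which is a limit of the assay and not a number.
Compound 2 `O=C(CCc1ccccc1F)Nc1nc2ccccc2c(=O)s1`: in this assay compound 2 gives > 10000 nM, again a limit rather than a measured number.

For the measured compounds named here, compound 2 thus stands at the edge of what this assay can report, and the only other value shown sits there as well, as the limit of > 10000 nM in this assay, at which 2 of the 2 values shown sit, records. Going by the values given here, the single measured step, a step that the two limits leave unreadable from compound 1 to compound 2, cannot be read in size, since both of its ends are limits. The step toward compound 3 `O=C(CCc1ccc(Cl)c(Cl)c1)Nc1nc2ccccc2c(=O)s1` is 3,4-dichlorophenyl in place of 2-fluorophenyl on a saturated chain carbon, two bonds along the chain from a carbonyl carbon. No measured step bears directly on this change; the two compounds already measured, both carrying a halogenated ring on the same chain, sit at the limit, and no swap among such rings has yet shown a readable shift. Compound 3 is therefore expected to remain near that limit, with the step that the limit leaves unreadable from compound 2 to compound 3 estimated to be no larger than the scatter. The estimate for compound 3 in this assay is 15000 nM, with an expected range from 3000 nM to 60000 nM.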

Compound 3, inhibition constant: > 1500 nM
Compound 3 was reported as a limit; the forecaster's own chance of this, stated with the estimate: 70%; the middle value is on the limit's open side.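

In this assay compound 3 gives > 1500 nM, which is a limit of the assay and not a number. For the compounds shown here, the values of compound 1, compound 2 and compound 3 are all limits, and no step among them can be read in size. The compounds shown leave open how 3,4-dichlorophenyl truly compares with 2-fluorophenyl or 2-bromophenyl on this chain.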